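Amide in Place of Ester at the Chain Carbonyl

The source may hold more compounds than are shown below. What is called first, only, known or untested is meant among the compounds shown, and "the series" means these compounds.

Going by the values given here, compound 2 `CC1(C)CC(OC(=O)CN2CN(c3ccccc3)C3(CCN(C(=O)c4ccc(C(C)(C)C)cc4)CC3)C2=O)CC(C)(C)N1` gives 1300 nM in an assay on HEK293 cells for displacement of a labelled ligand from NPC1-like intracellular cholesterol transporter 1 (Homo sapiens) (on this read-out higher numbers stand for weaker inhibition and lower numbers for stronger inhibition), the lowest of the two numbers known so far. Among the compounds with values here, its only neighbour, compound 1 `CC(C)(C)c1ccc(C(=O)N2CCC3(CC2)C(=O)N(CC(=O)NCN)CN3c2ccccc2)cc1`, gives 26500 nM, and the step of a 20-fold lower number from compound 1 to compound 2 (1.31 log units; beyond the scatter) is the single change measured at this carbonyl carbon. Compound 3 `CCOC(=O)C1CCN(C(=O)CN2CN(c3ccccc3)C3(CCN(C(=O)c4ccc(C(C)(C)C)cc4)CC3)C2=O)CC1` differs from compound 2 by 4-(ethoxycarbonyl)piperidin-1-yl in place of (2,2,6,6-tetramethylpiperidin-4-yl)oxy on a carbonyl carbon. Within the data shown here, because the one measured step, a 20-fold lower number from compound 1 to compound 2 (1.31 log units; beyond the scatter), shows that an exchange at this very position can move the number by a large margin, and because compound 1 with 26500 nM also carries a nitrogen rather than an oxygen on that carbonyl, a step back toward weaker inhibition is expected; its size is uncertain. The step of a 3.8-fold higher number from compound 2 to compound 3 (0.59 log units; beyond the scatter) is therefore estimated as a moderate rise. For compound 3 the expected value in this assay is 5000 nM, with a range from 1500 nM to 20000 nM.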

Compound 3, half-maximal inhibitory concentration: 3100 nM
Beside the measured number, compound 3's estimate is 1.6-fold (0.21 log units) above it, within the range that was stated.
By their numbers in this assay, from the lowest: compound 2; then compound 3; then compound 1.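

In this assay, moving the carbonyl carbon from an oxygen-linked to a nitrogen-linked ring substituent of equal heavy-atom count gives a 2.4-fold higher number from compound 2 to compound 3 (0.38 log units; beyond the scatter) and so costs far less than the earlier exchange at this position. Compound 3 also shows that a nitrogen on this carbonyl is compatible with much stronger inhibition than compound 1 displays, with an 8.5-fold lower number from compound 1 to compound 3 (0.93 log units; beyond the scatter) on replacing (aminomethyl)amino by 4-(ethoxycarbonyl)piperidin-1-yl. No measurement at hand accounts for either step.

The compounds shown leave open whether the ethoxycarbonyl group itself matters, as a plain piperidin-1-yl or a ring bearing a carboxylic acid in its place would show. They also leave open how a 2,2,6,6-tetramethylpiperidin-4-yl group joined through an amide nitrogen would compare with the oxygen-linked group of compound 2.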